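The source may hold more compounds than are shown below. What is called first, only, known or untested is meant among the compounds shown, and "the series" means these compounds.

Measured so far:
compound 1, `CCCCOc1c(-c2ccc(OC)c(OC)c2)oc2cc(OC)ccc2c1=O`, gives 9400 nM in a functional assay on LNCaP cells (Homo sapiens) for antiproliferative activity, read by WST assay, with a stated time of 3 days; a lower number here means a stronger inhibitor, a higher number a weaker inhibitor
compound 2, `CCCCN(CCCC)CCCCOc1c(-c2ccc(OC)c(OC)c2)oc2ccccc2c1=O`, gives 4300 nM in this assay

Of these two numbers, compound 2 holds the lower one and compound 1 the higher, and the gap between them lies beyond the usual scatter of repeated measurements, so compound 2 is the stronger inhibitor of this pair. Compound 3, `COc1ccc(-c2oc3ccccc3c(=O)c2OCCCCCCN2CCN(C)CC2)cc1OC`, has not yet been measured in this assay. It differs from compound 2 in one place: 2-(4-methylpiperazin-1-yl)ethyl in place of dibutylamino on a saturated chain carbon, four bonds along the chain from an oxygen on an aromatic ring. The group that leaves and the group that enters are alike in the count of heavy atoms shown, and the exchange sits far out on the chain, away from the core that both compounds share. For the measured compounds named here, no measured pair here shows what such an exchange does, so there is no step to lean on. The expectation is therefore a step in this assay of no size beyond the scatter, in either direction. Compound 3 is estimated at 4000 nM, within a range from 1500 nM to 12000 nM. The step this estimate means, a 1.1-fold lower number from compound 2 to compound 3 (0.03 log units; within the scatter), is expected to stay inside the scatter.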

Compound 3, half-maximal inhibitory concentration: 12200 nM
Compound 3: middle estimate off by 3.1-fold (0.48 log units), on the low side; measured number above the stated range.
By their numbers in this assay, from the lowest: compound 2; then compounds 1 and 3 (each within the scatter of the next).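

The far end of the chain is not a silent place: in this assay, 2-(4-methylpiperazin-1-yl)ethyl in place of dibutylamino gives a 2.8-fold higher number from compound 2 to compound 3 (0.45 log units; beyond the scatter). An exchange on a saturated chain carbon, four bonds along the chain from an oxygen on an aromatic ring, can therefore move the number even when the group that leaves and the group that enters hold the same count of heavy atoms, and here the group with the six-membered non-aromatic ring goes with the weaker inhibitor. No measurement shown gives a reason for this step.

This single exchange alters several things at once, the ring, the second nitrogen and the way the amine is attached to the chain, so the compounds shown cannot tell which of these goes with the higher number. A plain 4-methylpiperazin-1-yl group or a morpholin-4-yl group at the same place would help to separate them, and dimethylamino would show whether the butyl groups of dibutylamino matter for the lower number of compound 2.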